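Fluoroisoquinoline thiosemicarbazones: methyl-to-hydrogen step on the thioamide nitrogen

The source may hold more compounds than are shown below. What is called first, only, known or untested is meant among the compounds shown, and "the series" means these compounds.

Measured so far in a functional assay on MIA PaCa-2 cells (Homo sapiens) for cytotoxicity, read by luminescence, with a stated time of 72 h; on this read-out higher numbers stand for weaker inhibition and lower numbers for stronger inhibition:
compound 1, `CNC(=S)N/N=C/c1nccc2cc(F)ccc12`, 4080 nM
compound 2, `NC(=S)N/N=C/c1nccc2cc(F)ccc12`, 5440 nM
compound 3, `CNC(=S)N/N=C/c1ncc(F)c2ccccc12`, 2080 nM

Compound 1 and compound 3 are built from the same atoms joined differently; the difference between the two cores is not broken down here. Compound 3 gives the lowest of the three numbers, but its gap to compound 1 lies within the scatter, so no order between them is claimed; only its gap to compound 2 lies beyond it.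

Compound 2 differs from compound 1 by hydrogen in place of methyl on an amide-type nitrogen, and in this assay that change made a 1.3-fold higher number from compound 1 to compound 2 (0.12 log units; within the scatter), a step inside the scatter. Compound 4, `NC(=S)N/N=C/c1ncc(F)c2ccccc12`, not yet measured, differs from compound 3 by hydrogen in place of methyl on an amide-type nitrogen, the same change at the same place, on an amide-type nitrogen whose other neighbour is the thiocarbonyl carbon.

Going by the values given here, for compound 4 the expected step is a 1.3-fold higher number from compound 3 to compound 4 (0.11 log units; within the scatter), resting on the single earlier instance a 1.3-fold higher number from compound 1 to compound 2 (0.12 log units; within the scatter), with no second example to test whether the step carries over to the core of compound 3. Compound 4 is thus estimated at 2700 nM, with a plausible band from 1300 nM to 5600 nM.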

Compound 4, concentration for 90% inhibition: 24600 nM
For compound 4 the middle estimate is 9.1-fold (0.96 log units) below the measured one; the whole stated range lies below it.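

In this assay, hydrogen in place of methyl on the amide-type nitrogen gave a 12-fold higher number from compound 3 to compound 4 (1.07 log units; beyond the scatter), so the size of the step seen on the core of compound 1 did not carry over to the core of compound 3: the same change on two cores in this assay, a 1.3-fold higher number (0.12 log units; within the scatter) from compound 1 to compound 2 and a 12-fold higher number (1.07 log units; beyond the scatter) from compound 3 to compound 4, 8.9-fold (0.95 log units) apart, beyond the scatter of two such steps

A step read on one of these cores therefore gives no safe estimate for the other: the methylamino to amino change is resolved on the core of compound 3, but not on the core of compound 1. Going by these compounds alone, with a single pair on each core, this shows only that the step differs between these two cores; it does not show which difference between the cores goes with the larger step, or how the change would behave on a further core.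

Still open, going by these compounds, is whether the large step on the core of compound 3 is particular to methyl, or whether an ethyl or a longer chain on that nitrogen would hold the number near that of compound 3. A dimethylamino group in the same place would also test whether one remaining hydrogen on that nitrogen matters.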